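Working notes: one group exchanged on compound 2

The source may hold more compounds than are shown below. What is called first, only, known or untested is meant among the compounds shown, and "the series" means these compounds.

Measured so far in a functional assay on DU-145 cells (Homo sapiens) for antiproliferative activity, read by propidium iodide staining, with a stated time of 96 h; a lower number here means a stronger inhibitor, a higher number a weaker inhibitor
- compound 1 (`CC(O)(CSc1ccccc1OC(F)(F)F)C(=O)Nc1cccc(S(F)(F)(F)(F)F)c1`) (17500 nM)
- compound 2 (`CC(O)(COc1ccc(S(F)(F)(F)(F)F)cc1)C(=O)Nc1ccc(S(F)(F)(F)(F)F)cc1`) (24900 nM)

Compound 2 lies within the scatter of compound 1, so the two values do not separate. Compound 3 (`CC(O)(COc1ccc(OC(F)(F)F)cc1)C(=O)Nc1ccc(S(F)(F)(F)(F)F)cc1`) keeps the rest of compound 2 and exchanges one group (a group of 5 heavy atoms (1 carbon, 1 oxygen, 3 fluorine; no ring) in place of a group of 6 heavy atoms (5 fluorine, 1 sulfur; no ring), on an aromatic carbon). Trifluoromethoxy enters on an aromatic carbon, para to a large group. Within the data shown here, no measured pair isolates this exchange, so the data give no direct size for it. Compound 1 also carries a trifluoromethoxy group, and its value (17500 nM) sits within the scatter of compound 2, although the two differ elsewhere too. In this assay no step beyond the scatter is expected, in either direction. The estimated change is a 1.2-fold lower number from compound 2 to compound 3 (0.10 log units; within the scatter) and is expected to stay within the scatter. For compound 3 the estimated value is 20000 nM, with an expected range from 9000 nM to 42000 nM.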

Compound 3, half-maximal inhibitory concentration: 24800 nM
Compound 3: the middle estimate sits 1.2-fold (0.09 log units) below what was measured, and the stated range covers the measured number.
By their numbers in this assay, from the lowest: compounds 1, 3 and 2 (each within the scatter of the next).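

In this assay, trifluoromethoxy in place of the group of 6 heavy atoms (5 fluorine, 1 sulfur), on an aromatic carbon para to a large group, gives a 1.0-fold lower number from compound 2 to compound 3 (0.00 log units; within the scatter), so this exchange now has a direct reading rather than an inference from compounds that differ elsewhere too. At this position, the exchange leaves the number within the scatter even though the entering group carries 1 hydrogen-bond acceptor and the leaving group carries 0. No measurement available here accounts for this result.

The compounds shown leave open how an amine, a carboxylic acid or a longer chain would read on this aromatic carbon. They also leave open whether any exchange at this position can move the number beyond the scatter.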